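Cytotoxicity notes on the lactam series: sulfonamide extension

This account rests on a few compounds, and the source may have more. Where it says the series, first, only, none or still open, it means among the compounds named here.

Working notes on the series. The shared core is seen in compound 1 `COc1ccc([C@H]2CC(=O)N(c3ccccn3)C2)cc1OC1CCCC1`, where the amide-type nitrogen in the ring carries a pyridin-2-yl group; compound 2 `COc1ccc([C@H]2CC(=O)N(c3ccncc3)C2)cc1OC1CCCC1` carries pyridin-4-yl there and compound 3 `COc1ccc([C@H]2CC(=O)N(c3cccc(S(C)(=O)=O)c3)C2)cc1OC1CCCC1` carries 3-(methylsulfonyl)phenyl. In a functional assay on HEK293 cells (Homo sapiens) for cytotoxicity (on this read-out lower numbers stand for higher toxicity in this test and higher numbers for lower toxicity in this test), compound 1 gives only a limit, > 10000 nM. Compound 2 likewise gives only a limit in this assay, > 10000 nM. Compound 3 too sits at a limit in this assay, > 10000 nM. Hence the steps a step that the two limits leave unreadable from compound 1 to compound 2, a step that the two limits leave unreadable from compound 1 to compound 3 and a step that the two limits leave unreadable from compound 2 to compound 3 cannot be read; all that the numbers show is the limit of > 10000 nM in this assay, at which 3 of the 3 values shown sit.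

Compound 4 `COc1ccc([C@H]2CC(=O)N(c3cccc(NS(=O)(=O)c4ccccc4F)c3)C2)cc1OC1CCCC1` is not yet measured. It differs from compound 3 in one place: ((2-fluorophenyl)sulfonyl)amino in place of methylsulfonyl on an aromatic carbon. The steps measured so far all concern the aromatic substituent on that nitrogen, and none of them is readable, so nothing in the series sizes the effect of the entering group. The expectation is therefore that compound 4 also sits at the limit, with an expected step that the limit leaves unreadable from compound 3 to compound 4 that does not go beyond scatter. For compound 4 the estimate in this assay is 12000 nM, ranging from 5000 nM to 30000 nM.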

Compound 4, half-maximal cytotoxic concentration: > 10000 nM
Compound 4 gave a limit, no number; the forecaster's own chance of this, stated with the estimate: 75%; the middle value is on the limit's open side.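

In this assay compound 4 gives only a limit, > 10000 nM, so the step from compound 3 to compound 4 cannot be read, and no new step emerges: the limit of > 10000 nM in this assay, at which 4 of the 4 values shown sit.

The compounds shown leave open whether any substituent at these places gives a numerical value in this assay, and therefore how large any of these steps is.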